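A few compounds are considered here, and "the series" means these few. Any claim that something is new, unique, unknown or untested is made for them only; others in the source may bear on it.

Series notes. The shared core carries two hydroxyphenyl-bearing chains and an amine substituent that varies. Compound 1 is `COCCNC(=C\C(=O)/C=C/c1ccc(O)cc1)/C=C/c1ccc(O)cc1`; in a functional assay on Caco-2 cells (Homo sapiens) for cytotoxicity, read by MTT assay, with a stated time of 48 h (on this read-out higher numbers stand for weaker inhibition and lower numbers for stronger inhibition), compound 1 gives 28000 nM. Compound 2 is `COCCCNC(=C\C(=O)/C=C/c1ccc(O)cc1)/C=C/c1ccc(O)cc1`, differing only in the amine substituent; in this assay compound 2 gives 24000 nM. Going by the values given here, the one measured step, a 1.2-fold lower number from compound 1 to compound 2 (0.07 log units; within the scatter), stays within the scatter, so compound 2 and compound 1 are not separated on this read-out, and compound 2 stands beside compound 1 with nothing to distinguish the two numbers.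

Compound 3 is `O=C(/C=C(/C=C/c1ccc(O)cc1)NCCO)/C=C/c1ccc(O)cc1`. Relative to compound 2 the change is hydroxy in place of methoxymethyl on a saturated chain carbon, two bonds along the chain from an amine nitrogen. Among the compounds with values here, the only step available on the same chain position is a 1.2-fold lower number from compound 1 to compound 2 (0.07 log units; within the scatter), and it did not move the number beyond the scatter. Within the data shown here, no measured pair tests the entering hydroxy, so the expectation rests on the single flat step alone. For compound 3 the expected step is a 1.1-fold higher number from compound 2 to compound 3 (0.03 log units; within the scatter), that is, no change beyond the scatter in either direction. The estimate for compound 3 in this assay is 26000 nM, with a range from 12000 nM to 55000 nM.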

Compound 3, half-maximal inhibitory concentration in the Caco-2 assay: 57900 nM
Compound 3: the middle estimate sits 2.2-fold (0.35 log units) below what was measured; the measured number lies above the stated range.
By their numbers in the Caco-2 assay, from the lowest: compounds 2 and 1 (each within the scatter of the next); then compound 3.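

The position is not flat after all: the methoxy to methoxymethyl step left the number within the scatter, but in the Caco-2 assay the entering hydroxy gives a 2.4-fold higher number from compound 2 to compound 3 (0.38 log units; beyond the scatter), and the tighter comparison, hydrogen in place of methyl on the oxygen, gives a 2.1-fold higher number from compound 1 to compound 3 (0.32 log units; beyond the scatter). Compound 3 is therefore separated from both ethers, and the second step shows that a methyl on that oxygen is enough to make the difference, with no change in the chain. In a physicochemical assay for solubility, using the shake flask method, in phosphate buffer, with a stated time of 24 h, at pH 6.8 (on this read-out higher numbers stand for higher solubility and lower numbers for lower solubility), compound 2 gives 14900 nM and compound 3 gives 37900 nM, so the weaker inhibition of compound 3 comes with a higher solubility, a link that rests on two compounds only: the measured solubility of compound 2, 14900 nM, and of compound 3, 37900 nM, a 2.5-fold higher number (0.41 log units; beyond the scatter)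

Two compounds cannot show whether solubility and the cytotoxicity number are causally tied, or whether both simply follow the same change. Going by these compounds, it also remains open whether the step holds for a 3-hydroxypropyl chain, or for an amine or a carboxylic acid at the end of the chain in place of the hydroxy.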